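From Ethoxy to Trifluoromethyl: What to Expect

The source may report more compounds than this note shows. Statements on the series, on what has been measured and on what is new or still open speak of the compounds shown alone.

Among the measured compounds shown here, in a physicochemical assay for lipophilicity, read by HPLC, at pH 7.5 (a lower number here means a more polar compound, a higher number a more lipophilic compound), compound 1 `CCOc1ccccc1-c1ccc(-c2nc3cnccc3c(N[C@H](CC)C(N)=O)c2C#N)cc1` gives 3, the highest of the three numbers measured so far. Compound 3 `CCOc1ccccc1-c1ccc(-c2nc3cnccc3c(N[C@@H]3CCOC3=O)c2C#N)cc1` gives 2.7, and compound 2 `CCOc1ccccc1-c1ccc(-c2nc3cnccc3c(C[C@H](C)C(=O)O)c2C#N)cc1` gives 2.2. The three measured steps, a number 0.30 log units lower from compound 1 to compound 3 (within the scatter), a number 0.80 log units lower from compound 1 to compound 2 (beyond the scatter) and a number 0.50 log units higher from compound 2 to compound 3 (beyond the scatter), all concern a different part of the molecule from the one changed here, so none of them speaks directly to the present step. Compound 4 `CC[C@@H](Nc1c(C#N)c(-c2ccc(-c3ccccc3C(F)(F)F)cc2)nc2cnccc12)C(N)=O` differs from compound 1 by trifluoromethyl in place of ethoxy on an aromatic carbon. For the measured compounds named here, with no measured step at this place, the expectation rests on the change itself, and a modest rise is estimated, namely a number 0.50 log units higher from compound 1 to compound 4 (beyond the scatter). Compound 4 is therefore expected to give 3.5, with a range from 3.1 to 3.9.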

Compound 4, distribution coefficient: 3.1
Estimate against measurement, compound 4: 0.40 log units above; the range from low to high includes it.
By their numbers in this assay, from the lowest: compound 2; then compounds 3, 1 and 4 (each within the scatter of the next, the first and the last beyond it).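

In this assay, among the compounds shown here, trifluoromethyl in place of ethoxy gives a number 0.10 log units higher from compound 1 to compound 4 (within the scatter), the first reading at this position. On this ring, ortho to a large group, a swap that removes the hydrogen-bond acceptor of ethoxy leaves no difference that this measurement can separate. Nothing measured here offers a reason for this match.

Going by these compounds, whether an amine, a carboxylic acid or a longer chain such as propoxy at this place would also read alike stays open. So does whether trifluoromethyl and ethoxy would still match with the side chains of compound 2 or compound 3.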